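Extending the butenamide of compound 2 with a methylpiperazine

This account rests on a few compounds, and the source may have more. Where it says the series, first, only, none or still open, it means among the compounds named here.

Among the three measured analogues, compound 2 `CC/C=C/C(=O)Nc1cc2c(N3CCCc4ccccc43)ncnc2cc1OC` shows the lowest number, with 5030 nM in a functional assay on A549 cells (Homo sapiens) for antiproliferative activity, read by MTT assay, with a stated time of 72 h; a higher number here means a weaker inhibitor, a lower number a stronger inhibitor. Compound 1 `C=CC(=O)Nc1cc2c(N3CCc4ccccc43)ncnc2cc1OC` gives 5580 nM, which lies within the scatter of compound 2. Going by the values given here, compound 3 `CC/C=C/C(=O)Nc1cc2c(N3CCCc4ccccc43)ncnc2cc1O[C@@H]1CCOC1` gives 14100 nM, and the step of a 2.8-fold higher number from compound 2 to compound 3 (0.45 log units; beyond the scatter) is the only one-point change measured so far. Compound 4 `COc1cc2ncnc(N3CCCc4ccccc43)c2cc1NC(=O)/C=C/CN1CCN(C)CC1` differs from compound 2 in another place: 4-methylpiperazin-1-yl in place of methyl on a saturated chain carbon bound to a double-bonded chain carbon. Among the compounds with values here, no measured step touches this part of the molecule, so the expectation rests on compound 2 alone, with a wide range. Compound 4 is estimated at 3200 nM, spanning 800 nM to 12000 nM, which means an expected step of a 1.6-fold lower number from compound 2 to compound 4 (0.20 log units; within the scatter), not clearly beyond the scatter.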

Compound 4, half-maximal inhibitory concentration: 7830 nM
For compound 4 the middle estimate is 2.4-fold (0.39 log units) below the measured one; the measured number falls inside the stated range.
By their numbers in this assay, from the lowest: compounds 2, 1, 4 and 3 (each within the scatter of the next, the first and the last beyond it).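

In this assay, 4-methylpiperazin-1-yl in place of methyl on a saturated chain carbon bound to a double-bonded chain carbon gives a 1.6-fold higher number from compound 2 to compound 4 (0.19 log units; within the scatter) and so this position takes the larger ring-bearing group without a change beyond the scatter. The earlier step of a 2.8-fold higher number from compound 2 to compound 3 (0.45 log units; beyond the scatter) concerned only the group on oxygen on the aromatic ring, and says nothing about this chain. Nothing available here accounts for the result.

On these data alone, whether a dimethylamino group or a morpholine at this place would read alike remains open. So does the effect of pairing 4-methylpiperazin-1-yl with the oxolan-3-yl group of compound 3.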